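Chloro for methyl on the indazole of an acrylic acid series

The source may report more compounds than this note shows. Statements on the series, on what has been measured and on what is new or still open speak of the compounds shown alone.

Measured compounds:
Compound 1 `O=C(O)/C=C/c1ccc(/C(=C(/CCCl)c2ccccc2)c2ccc3[nH]ncc3c2)cc1` gives 9 nM in a functional assay on MCF7 cells (Homo sapiens) for cytotoxicity, read by CellTiter-Glo, with a stated time of 5 days; on this read-out lower numbers stand for stronger inhibition and higher numbers for weaker inhibition.
Compound 2 `CC/C(=C(/c1ccc(/C=C/C(=O)O)cc1)c1cc2cn[nH]c2cn1)c1ccccc1` gives 442 nM in this assay.
Compound 3 `CC/C(=C(/c1ccc(/C=C/C(=O)O)cc1)c1cc(C)c2[nH]ncc2c1)c1ccccc1` gives 59 nM in this assay.

Compound 3 stands second highest among the three numbers. Its nearest neighbour is compound 1, whose number is lower, and the furthest is compound 2, whose number is higher; both gaps lie beyond the scatter. Compound 4 `CC/C(=C(/c1ccc(/C=C/C(=O)O)cc1)c1cc2cn[nH]c2cc1Cl)c1ccccc1` has not yet been measured. It differs from compound 3 in one place: 6-chloro-1H-indazol-5-yl in place of 7-methyl-1H-indazol-5-yl on a double-bonded chain carbon bound to an aromatic carbon and a double-bonded chain carbon.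

Among the measured compounds shown here, only one step in this set is measured between compounds that differ in one place, a 7.5-fold lower number from compound 2 to compound 3 (0.87 log units; beyond the scatter), and it exchanges a whole bicyclic group rather than a substituent on it. For the measured compounds named here, no measured step exchanges a methyl for a chlorine on the same ring system, so nothing in the data bears directly on the change from compound 3 to compound 4. Going by the values given here, compound 1 carries the unsubstituted indazol-5-yl but also a different chain, so its value shows only that this ring system can sit in a compound with a low number.

Among the compounds with values here, with no direct precedent, the expected step from compound 3 to compound 4 is a 1.2-fold lower number from compound 3 to compound 4 (0.07 log units; within the scatter), which is not beyond the scatter. Compound 4 is therefore estimated at 50 nM, with a range from 15 nM to 170 nM.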

Compound 4, half-maximal inhibitory concentration: 137 nM
For compound 4 the middle estimate is 2.7-fold (0.44 log units) below the measured one, within the range that was stated.
By their numbers in this assay, from the lowest: compound 1; then compound 3; then compound 4; then compound 2.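

In this assay, the change from 7-methyl-1H-indazol-5-yl to 6-chloro-1H-indazol-5-yl on the shared core is not neutral (a 2.3-fold higher number from compound 3 to compound 4 (0.37 log units; beyond the scatter)), even though the two groups match in heavy atoms, hydrogen-bond donors and hydrogen-bond acceptors. The chlorine-bearing group also keeps an advantage over the group of compound 2, whose six-membered aromatic ring carries 1 hetero atom (a 3.2-fold lower number from compound 2 to compound 4 (0.51 log units; beyond the scatter)), so two different groups with a six-membered aromatic ring of carbon only now give lower numbers than compound 2 on this core. No measurement offered here explains why the chlorine-bearing group falls short of the methyl-bearing one.

The names of the two groups differ in both the substituent and the number of its position, and the compounds shown cannot separate these two changes. As far as these compounds go, it also remains open how a fluorine, a methoxy group or a nitrile would compare with the chlorine of 6-chloro-1H-indazol-5-yl, and how plain 1H-indazol-5-yl would stand on the core of compound 3.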